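This account rests on a few compounds, and the source may have more. Where it says the series, first, only, none or still open, it means among the compounds named here.

Working notes. Compound 1 `ClCc1ccc(Cn2cnc3c(Cl)ncnc32)cc1` in a functional assay on RXF 393 cells (Homo sapiens) for cytotoxicity, read by sulforhodamine B assay, with a stated time of 48 h (a higher number here means a weaker inhibitor of growth, a lower number a stronger inhibitor of growth), gives 5490 nM and stands at the low end of the two numbers recorded; compound 2 `ClCc1ccccc1Cn1cnc2ncnc(Cl)c21` gives 6540 nM, which lies within the scatter of compound 1, so the pair shows no separation. Compound 3 `ClCc1ccc(Cn2cnc3c(Cl)nc(Cl)nc32)cc1` differs from compound 1 by chloro in place of hydrogen on an aromatic carbon. Going by the values given here, no measured step of this kind exists in the set. The expected step of a 1.6-fold lower number from compound 1 to compound 3 (0.20 log units; within the scatter) is modest, toward a lower number, but may well stay within the scatter. Compound 3 is estimated at 3500 nM, ranging from 1200 nM to 9000 nM.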

Compound 3, concentration for total growth inhibition: 41700 nM
For compound 3 the middle estimate is 12-fold (1.08 log units) below the measured one; measured number outside the range, above it.
By their numbers in this assay, from the lowest: compounds 1 and 2 (each within the scatter of the next); then compound 3.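

In this assay, chloro in place of hydrogen on an aromatic carbon, between two ring nitrogen atoms, gives a 7.6-fold higher number from compound 1 to compound 3 (0.88 log units; beyond the scatter) and so yields the first separation in the series beyond the scatter. This position is therefore not neutral to substitution: chloro here leaves a weaker inhibitor of growth than hydrogen does. No measurement at hand accounts for the shift. Going by these compounds, whether an amine or a methoxy group at this position would follow chloro stays open, as does whether the same change would have a like effect on compound 2.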